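Phenyl in Place of Bromo: What Compound 4 Should Give

The source may hold more compounds than are shown below. What is called first, only, known or untested is meant among the compounds shown, and "the series" means these compounds.

Three amides share one core and were tested in a functional assay on HCC1937 cells (Homo sapiens) for antiproliferative activity, read by CCK-8 assay, with a stated time of 72 h; on this read-out higher numbers stand for weaker inhibition and lower numbers for stronger inhibition. Compound 1 `O=C(Nc1cccc(-c2oc3cc(-c4ccc(F)cc4)ccc3c(=O)c2O)c1)c1ccccc1F` gives 10800 nM; compound 2 `O=C(Nc1cccc(-c2oc3cc(-c4ccc(F)cc4)ccc3c(=O)c2O)c1)c1ccc(Br)cc1` gives 8630 nM; compound 3 `O=C(Nc1cccc(-c2oc3cc(-c4ccc(F)cc4)ccc3c(=O)c2O)c1)c1ccc([N+](=O)[O-])cc1` gives 5640 nM. On these numbers compound 2 stands second highest of the three, with a 1.3-fold lower number from compound 1 to compound 2 (0.10 log units; within the scatter) and a 1.5-fold lower number from compound 2 to compound 3 (0.18 log units; within the scatter), both within the scatter, as is a 1.9-fold lower number from compound 1 to compound 3 (0.28 log units; within the scatter). Compound 4 `O=C(Nc1cccc(-c2oc3cc(-c4ccc(F)cc4)ccc3c(=O)c2O)c1)c1ccc(-c2ccccc2)cc1` differs from compound 2 by phenyl in place of bromo on an aromatic carbon. Among the compounds with values here, no measured step exchanges bromo for phenyl, and every measured change of this aryl amide group stayed within the scatter, so compound 4 is expected to show no step beyond the scatter, a 1.2-fold lower number from compound 2 to compound 4 (0.09 log units; within the scatter). Compound 4 is therefore estimated at 7000 nM, within a range from 2500 nM to 20000 nM.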

Compound 4, half-maximal inhibitory concentration: 44100 nM
For compound 4 the middle estimate is 6.3-fold (0.80 log units) below the measured one; measured number outside the range, above it.
By their numbers in this assay, from the lowest: compounds 3, 2 and 1 (each within the scatter of the next); then compound 4.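

At this place on the aryl amide group, the number can move after all. In this assay, phenyl in place of bromo gives a 5.1-fold higher number from compound 2 to compound 4 (0.71 log units; beyond the scatter), and phenyl in place of nitro gives a 7.8-fold higher number from compound 3 to compound 4 (0.89 log units; beyond the scatter). The third comparison gives a 4.1-fold higher number from compound 1 to compound 4 (0.61 log units; beyond the scatter), so the 4-phenylphenyl group stands apart from the other three aryl groups, which lie within the scatter of one another.

From the compounds shown here alone, it remains open whether a non-aromatic ring such as cyclohexyl or morpholine, or an amine or a carboxylic acid, would behave like phenyl or like bromo at this place. Nothing measured here accounts for the step.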